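Swapping trifluoromethyl for dimethylcarbamoyl on a shared core

This account rests on a few compounds, and the source may have more. Where it says the series, first, only, none or still open, it means among the compounds named here.

Three compounds with a shared core have been examined in an in vitro ADME assay on microsomes from liver (Homo sapiens) for metabolic stability; a lower number here means that the compound disappears faster, a higher number that the compound lasts longer. Compound 1 `COc1ccc(-c2cc(-c3ccc(S(C)(=O)=O)c(F)c3)cnc2N)cn1` gives > 4.16 h, which is a limit of the assay and not a number. Compound 3 `COc1ccc(-c2cc(-c3cccc(C(N)=O)c3)cnc2N)cn1` likewise gives > 4.16 h, again a limit rather than a number. Compound 2 `COc1ccc(-c2cc(-c3ccc(C(F)(F)F)cc3)cnc2N)cn1` is the only one of the three with an actual number, 4.75 h in this assay, and it stands alone in that respect; the other two results sit at the limit of > 4.16 h in this assay, at which 2 of the 3 values shown sit. Among the compounds with values here, no pair among the measured compounds differs in a single place, so no measured step is available.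

Compound 4 `COc1ccc(-c2cc(-c3ccc(C(=O)N(C)C)cc3)cnc2N)cn1` has not yet been tested. Its change from compound 2 is dimethylcarbamoyl in place of trifluoromethyl on an aromatic carbon. Compound 3, which carries a carbamoyl group, reaches the limit in this assay. On this basis the step from compound 2 to compound 4 is expected to be a 1.3-fold lower number from compound 2 to compound 4 (0.10 log units; within the scatter), that is, nothing beyond the usual scatter. For compound 4 the expected half-life is 3.8 h, within a range from 1.5 h to 8 h, with a fair chance that the assay again reports only a limit.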

Compound 4, half-life: 2.6 h
The estimate for compound 4 lay 1.5-fold (0.16 log units) above the measured number; the range from low to high includes it.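

With compound 4, this aromatic carbon, para to a large group, gets its first measured step: in this assay, dimethylcarbamoyl in place of trifluoromethyl gives a 1.8-fold lower number from compound 2 to compound 4 (0.26 log units; within the scatter). Exchanging a group with no hydrogen-bond acceptor for one that has a hydrogen-bond acceptor therefore leaves the two half-lives within the usual scatter of each other, although this reading rests on a single pair. Steps to compound 1 and compound 3 cannot be read, as their results are limits of the assay and not numbers: the limit of > 4.16 h in this assay, at which 2 of the 4 values shown sit.

The compounds shown leave open how a nitrile, a carboxylic acid or an amine on this same aromatic carbon would compare with trifluoromethyl. They also leave open whether the exchange would give a similar step on a core other than the shared one.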